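A few compounds are considered here, and "the series" means these few. Any claim that something is new, unique, unknown or untested is made for them only; others in the source may bear on it.

Four compounds share a bicyclic lactam core bearing a carboxylic acid chain and an amide-linked aromatic ring; they differ in the outer ring and in one chain carbon. Compound 1 `O=C(O)CCN1Cc2ccc(NC(=O)c3ccc4c(c3)CNCC4)cc2C1=O` and compound 2 `CC(CC(=O)O)N1Cc2ccc(NC(=O)c3ccc4c(c3)CNCC4)cc2C1=O` carry the same outer ring, and compound 2 differs from compound 1 only by methyl in place of hydrogen on a saturated chain carbon bound to an amide-type nitrogen in a ring and a saturated chain carbon. In a functional assay on a cell-free system (Platelet, plasma, Homo sapiens) for inhibition (on this read-out lower numbers stand for stronger inhibition and higher numbers for weaker inhibition), compound 1 gives 1100 nM, while compound 2 gives 86 nM, so that a 13-fold lower number from compound 1 to compound 2 (1.11 log units; beyond the scatter).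

Compound 3 `O=C(O)CCN1Cc2ccc(NC(=O)c3ccc(N4CCNCC4)cc3)cc2C1=O` carries a different outer ring than compound 1; the difference between the two cores is not broken down here. In this assay compound 3 gives 540 nM, a higher number than compound 2 and a lower one than compound 1.

Compound 4 `CC(CC(=O)O)N1Cc2ccc(NC(=O)c3ccc(N4CCNCC4)cc3)cc2C1=O` is compound 3 with methyl in place of hydrogen on a saturated chain carbon bound to an amide-type nitrogen in a ring and a saturated chain carbon. This is the same change as the one from compound 1 to compound 2, at the same place, and it occurs twice among these compounds. For the measured compounds named here, only one measured step shows its size, so the expectation for compound 4 rests on a single pair; the step is expected to be an 11-fold lower number from compound 3 to compound 4 (1.03 log units; beyond the scatter), close to the earlier step, because a 13-fold lower number from compound 1 to compound 2 (1.11 log units; beyond the scatter). Compound 4 is therefore estimated at 50 nM in this assay, with a range from 18 nM to 170 nM. Whether the outer ring of compound 3 carries the methyl effect equally is not shown by any measured pair.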

Compound 4, half-maximal inhibitory concentration: 3740 nM
Beside the measured number, compound 4's estimate is 75-fold (1.87 log units) below it; measured number above the stated range.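

In this assay, methyl in place of hydrogen on the saturated chain carbon gives a 6.9-fold higher number from compound 3 to compound 4 (0.84 log units; beyond the scatter) on the core of compound 3, so the number moves in the opposite direction to the step on the core of compound 1. This change therefore cannot be carried from one core to the other in this series as a fixed gain or loss, since even its direction differs and the gap between the two steps is large: the same change on two cores in this assay, a 13-fold lower number (1.11 log units; beyond the scatter) from compound 1 to compound 2 and a 6.9-fold higher number (0.84 log units; beyond the scatter) from compound 3 to compound 4, 89-fold (1.95 log units) apart, beyond the scatter of two such steps. For the compounds shown here, with only two pairs, this shows that the effect of the methyl depends on the rest of the molecule, but it does not show which feature of the outer ring reverses the step, or which of the two directions would be more typical on a further core.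

From the compounds shown here alone, it remains open whether a third outer ring, for example one carrying a simple primary amine, would follow compound 2 or compound 4 when the methyl is added. Going by these compounds, it is also open whether an ethyl group on the same chain carbon would split the two cores in the same way as the methyl.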